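The compounds below may be only part of what the source reports. "The series", "measured", "known", "first", "only" and "open" are said of these compounds alone.

In a functional assay on MCF7 cells (Homo sapiens) for inhibition, read by sulforhodamine B assay, with a stated time of 48 h (a lower number here means a stronger inhibitor, a higher number a weaker inhibitor), compound 1 (`COc1ccc(C(O)(Cc2ccc(C)cc2)c2cccc3ccccc23)c(OC)c1OC`) gives > 20000 nM, which is a limit of the assay. Compound 2 (`CCOC(=O)CO/N=C(/c1ccc(OC)c(OC)c1OC)c1cccc2ccccc12`) gives > 20000 nM, also a limit. Compound 1 thus stands at the limit of > 20000 nM in this assay, at which 2 of the 2 values shown sit, and no number yet exists for the series. Compound 3 (`C=CCC(O)(c1ccc(OC)c(OC)c1OC)c1cccc2ccccc12`) keeps the core of compound 1 and differs in one place: vinyl in place of 4-methylphenyl on a saturated chain carbon, two bonds along the chain from two aromatic carbons and an oxygen on a saturated carbon. Read one bond further out, this is 4-methylbenzyl to allyl. Among the compounds with values here, no measured step covers this change, so the expected a number no higher from compound 1 to compound 3 (the limit leaves the size open) in this assay is small, if any, and toward a lower number. For compound 3 the estimate is 20000 nM, with an expected range of 8000 nM to 40000 nM.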

Compound 3, half-maximal inhibitory concentration: > 20000 nM
Compound 3 was reported as a limit (the forecaster's own chance of this, stated with the estimate: 65%); the middle value lies on the limit itself.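

No step from compound 1 to compound 3 can be read, since both values are limits of the assay: the limit of > 20000 nM in this assay, at which 3 of the 3 values shown sit.

The compounds shown leave open which change to the shared core, if any, gives a measurable number in this assay.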